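Swapping the Amide Amine: Expecting Little Change

A few compounds are considered here, and "the series" means these few. Any claim that something is new, unique, unknown or untested is made for them only; others in the source may bear on it.

Three measured compounds share one core and differ only in the group attached to the carbonyl carbon. Compound 1 `COc1cc2c(cc1OC)C(CC(=O)O)CC2` carries a free acid; in a functional assay on the whole organism (strain Wistar) for inhibition, with Rattus norvegicus as the target, read by paw edema, with stated times of 60 min and 3 h, at a dose of 100 mg/kg by the oral route (on this read-out higher numbers stand for more inhibition at the one dose given (going by the name of the read-out) and lower numbers for less inhibition), compound 1 gives 27.5%. Compound 2 `CCN(CC)C(=O)CC1CCc2cc(OC)c(OC)cc21` carries a diethylamino group there, and in this assay compound 2 gives 37.7%. Compound 3 `COc1cc2c(cc1OC)C(CC(=O)NC(C)C)CC2` carries an isopropylamino group; in this assay compound 3 gives 30.4%. On these numbers compound 3 stands second highest of the three, but its gaps to both other compounds lie within the scatter of the measurement, so nothing separates it clearly from either.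

The step to compound 4 `COc1cc2c(cc1OC)C(CC(=O)N1CCNCC1)CC2` is piperazin-1-yl in place of isopropylamino on a carbonyl carbon. Within the data shown here, three measured steps touch the same carbonyl carbon. Replacing the acid by an amine gave a number 10.2 percentage points higher from compound 1 to compound 2 (beyond the scatter) and a number 2.9 percentage points higher from compound 1 to compound 3 (within the scatter), while exchanging one amine for another gave a number 7.3 percentage points lower from compound 2 to compound 3 (within the scatter). Among the measured compounds shown here, only the step to the diethylamino amide rose beyond the scatter; the single amine-for-amine exchange stayed within it. Compound 4 is again an amine-for-amine exchange, so a change within the scatter is expected in this assay, in no particular direction, the expectation resting on the exchange that gave a number 7.3 percentage points lower from compound 2 to compound 3 (within the scatter).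

For compound 4 the estimate in this assay is 32%, with a range from 20% to 45%. That estimate means an expected step of a number 1.6 percentage points higher from compound 3 to compound 4 (within the scatter).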

Compound 4, a percentage reported as inhibition, in the whole organism at one dose (the size of the read-out at that dose, not a potency): 42%
Beside the measured number, compound 4's estimate is 10 percentage points below it; the range from low to high includes it.
By their numbers in this assay, from the lowest: compounds 1, 3, 2 and 4 (each within the scatter of the next, the first and the last beyond it).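

Among these compounds, the step of a number 11.6 percentage points higher from compound 3 to compound 4 (beyond the scatter) shows that in this assay swapping one amine for another on this carbonyl carbon can move the number beyond the scatter, which the only earlier exchange of this kind did not do. The step of a number 14.5 percentage points higher from compound 1 to compound 4 (beyond the scatter) makes compound 4 the second amide, after compound 2, to rise beyond the scatter from the free acid, with compound 3 going against that pattern, while a number 4.3 percentage points higher from compound 2 to compound 4 (within the scatter) leaves the piperazin-1-yl and diethylamino amides not separable from each other. Nothing on hand explains why the piperazin-1-yl group gives this step from the isopropylamino group.

A piperidin-1-yl or morpholin-4-yl group on the same carbonyl carbon would help show whether the rise goes with the six-membered ring alone or needs the second ring nitrogen of piperazin-1-yl. A 4-methylpiperazin-1-yl group would test whether that second nitrogen can carry a substituent, and the single dose leaves open how these amides would rank at other doses.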